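The compounds below may be only part of what the source reports. "The series", "measured", "known", "first", "only" and "open" are said of these compounds alone.

In an ADME assay on HEp-2 cells (Homo sapiens) for cytotoxicity, read by MTT assay, with a stated time of 72 h (on this read-out higher numbers stand for weaker inhibition and lower numbers for stronger inhibition), compound 1 `COc1ccc(C2=C(c3cc(OC)c(OC)c(OC)c3)CC(O)C2=O)cc1[N+](=O)[O-]` reads > 100 ug/mL as a limit of the assay. Compound 2 `COC(=O)c1cc(C2=C(c3cc(OC)c(OC)c(OC)c3)C(=O)CC2O[SiH2]C(C)(C)C)ccc1OC` reads > 100 ug/mL and this too is a limit, so compound 2 has no number of its own. Compound 3 `COc1ccc(C2=C(c3cc(OC)c(OC)c(OC)c3)C(=O)CC2O[SiH2]C(C)(C)C)cc1O` arises from compound 2 by hydroxy in place of methoxycarbonyl on an aromatic carbon with hydroxy in place of methoxycarbonyl on an aromatic carbon. Going by the values given here, no measured step sizes this change. A large move toward stronger inhibition is still expected, estimated as an at least 100-fold lower number from compound 2 to compound 3 (2.00 log units; beyond the scatter) with wide uncertainty. For compound 3 the estimated value is 1 ug/mL with 0.05 ug/mL to 50 ug/mL as the expected range.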

Compound 3, half-maximal inhibitory concentration: 14.5 ug/mL
For compound 3 the middle estimate is 15-fold (1.16 log units) below the measured one, and the stated range covers the measured number.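

In this assay hydroxy in place of methoxycarbonyl gives an at least 6.8-fold lower number from compound 2 to compound 3 (0.83 log units; beyond the scatter) on an aromatic carbon ortho to a methoxy group. This position is therefore the first in the series shown where a single change brings the read-out away from the limit. The step is only a floor because compound 2 has a limit and not a number: the limit of > 100 ug/mL in this assay, at which 2 of the 3 values shown sit.

Going by these compounds, whether the gain comes from adding hydroxy or from losing methoxycarbonyl remains open. A carboxylic acid or an amine at this position could help separate those two readings.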